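Hydrazone series: fluoro to bromo, cytotoxicity expectation

The source may hold more compounds than are shown below. What is called first, only, known or untested is meant among the compounds shown, and "the series" means these compounds.

The series shares one core, seen in compound 1 `O=C(COc1cccc2ccccc12)N/N=C/c1cccc(O)c1`, compound 2 `O=C(COc1cccc2ccccc12)N/N=C/c1ccccc1` and compound 3 `O=C(COc1cccc2ccccc12)N/N=C/c1ccc(F)cc1`. In an ADME assay on MT4 cells (Homo sapiens) for cytotoxicity, read by MTT assay, with a stated time of 4 days (on this read-out higher numbers stand for lower toxicity in this test and lower numbers for higher toxicity in this test), compound 1 gives 32.6 ug/mL and compound 3 gives 65.1 ug/mL. For compound 2 the value of >= 96.6 ug/mL is a limit of this assay and not a number. Compound 3 holds the highest of the two numbers; its nearest is compound 1, a 2.0-fold higher number from compound 1 to compound 3 (0.30 log units; within the scatter). Compound 4 `O=C(COc1cccc2ccccc12)N/N=C/c1ccc(Br)cc1` is not yet measured; it differs from compound 3 by bromo in place of fluoro on an aromatic carbon. For the measured compounds named here, the one measured step at the same aromatic carbon is an at least 1.4-fold lower number from compound 2 to compound 3 (0.17 log units; that floor lies within the scatter); the other, an at least 2.9-fold higher number from compound 1 to compound 2 (0.47 log units; beyond the scatter), concerns hydroxy. Exchanging one halogen for another is therefore expected to give a 1.3-fold lower number from compound 3 to compound 4 (0.11 log units; within the scatter), nothing beyond the scatter. Compound 4 is estimated at 50 ug/mL, between 25 ug/mL and 100 ug/mL.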

Compound 4, half-maximal cytotoxic concentration: 106 ug/mL
Compound 4: middle estimate off by 2.1-fold (0.33 log units), on the low side; the whole stated range lies below it.
By their numbers in this assay, from the lowest: compounds 1, 3 and 4 (each within the scatter of the next, the first and the last beyond it).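

Bromo in place of fluoro on the aromatic carbon para to a large group gives a 1.6-fold higher number from compound 3 to compound 4 (0.21 log units; within the scatter), so this halogen exchange stays inside the scatter. Against the hydroxy compound, the 4-bromophenyl group gives a 3.3-fold higher number from compound 1 to compound 4 (0.51 log units; beyond the scatter), a separation beyond the scatter that the 4-fluorophenyl group did not reach. Compound 2 holds a limit and not a number, so its step to compound 4 cannot be read: the limit of >= 96.6 ug/mL in this assay, at which 1 of the 4 values shown sits.

Going by these compounds, whether bromo differs from hydrogen at this carbon stays open. On these data alone, how an amine or a carboxylic acid would read at the same carbon also stays open.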